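The source may hold more compounds than are shown below. What is called first, only, known or untested is meant among the compounds shown, and "the series" means these compounds.

Measured in a physicochemical assay for solubility; on this read-out higher numbers stand for higher solubility and lower numbers for lower solubility:
- compound 1 `Nc1ccccc1NC(=O)c1ccc(CSC2=N[C@@H](c3ccccc3)CN2)cc1`: 116 ug/mL
- compound 2 `Nc1ccccc1NC(=O)c1ccc(CNC2=N[C@@H](c3ccccc3)CN2)cc1`: >= 70 ug/mL (a limit of the assay)
- compound 3 `Nc1ccccc1NC(=O)c1ccc(CNC2=NC(c3ccc(F)cc3)CO2)cc1`: 147 ug/mL

Compound 4 `Nc1ccccc1NC(=O)c1ccc(CNC2=NC(c3ccc(C(F)(F)F)cc3)CO2)cc1` has not yet been measured.

Only two of these results are actual numbers. In this assay compound 3 gives 147 ug/mL and compound 1 gives 116 ug/mL, and these two values lie within the scatter of each other. For compound 2 the read-out is only a limit, >= 70 ug/mL.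

The step of interest starts from compound 3. Compound 4 carries trifluoromethyl in place of fluoro on an aromatic carbon, para to a large group: trifluoromethyl in place of fluoro on an aromatic carbon.

For the measured compounds named here, no pair of measured compounds shows this change, so the expectation is a rough one. A small fall in this assay is expected, within or close to the scatter, and the estimated step is a 1.7-fold lower number from compound 3 to compound 4 (0.24 log units; within the scatter). For compound 4 the estimated value is 85 ug/mL, with an expected range from 30 ug/mL to 170 ug/mL.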

Compound 4, solubility: 8 ug/mL
The estimate for compound 4 lay 11-fold (1.03 log units) above the measured number, outside the stated range (below it).
By their numbers in this assay, from the lowest: compound 4; then compounds 1 and 3 (each within the scatter of the next).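

In this assay, for the compounds shown here, trifluoromethyl in place of fluoro on an aromatic carbon, para to a large group, gives an 18-fold lower number from compound 3 to compound 4 (1.26 log units; beyond the scatter), so this position is far from indifferent to what it carries, which no earlier pair of compounds could show. The change is a small one on paper: it adds three heavy atoms, with no ring, no hydrogen-bond donor or acceptor and no net charge entering or leaving. Nothing measured for these compounds accounts for a step of this size.

On these data alone, it remains open whether other groups at this position, such as a methyl, a methoxy or an amine, would stay close to compound 3 or fall as far as compound 4. As far as these compounds go, it is also open whether the same exchange would cost as much on the core of compound 1.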